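This account rests on a few compounds, and the source may have more. Where it says the series, first, only, none or still open, it means among the compounds named here.

Among the measured compounds shown here, compound 1 `Nc1nc2ccc(-c3cn([C@@H]4CN[C@H](C(=O)Nc5ccc(Cl)cc5Cl)C4)nn3)nc2s1` is the weaker of the two compounds measured so far in a functional assay on K562 cells (Homo sapiens) for inhibition, read by MTT assay, with a stated time of 48 h; a lower number here means a stronger inhibitor, a higher number a weaker inhibitor: compound 1 gives 24500 nM, and its nearest neighbour, compound 2 `CC(=O)Nc1nc2ccc(-c3cn([C@@H]4CN[C@H](C(=O)Nc5ccc(Cl)cc5Cl)C4)nn3)nc2s1`, gives 9670 nM. For the measured compounds named here, the only step measured between them, a 2.5-fold lower number from compound 1 to compound 2 (0.40 log units; beyond the scatter), concerns acetyl in place of hydrogen on a nitrogen on an aromatic ring and leaves the anilide part untouched.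

Compound 3 `Nc1nc2ccc(-c3cn([C@@H]4CN[C@H](C(=O)Nc5ccc(F)c(F)c5)C4)nn3)nc2s1` differs from compound 1 in exactly that anilide part: 3,4-difluorophenyl in place of 2,4-dichlorophenyl on an amide-type nitrogen. Going by the values given here, no measured step bears on this change, so the direction of any shift in this assay is unknown from these data, and the default expectation is a number close to that of compound 1.

Compound 3 is therefore expected to give about 30000 nM in this assay, within a wide range from 8000 nM to 100000 nM. This estimate corresponds to an expected step of a 1.2-fold higher number from compound 1 to compound 3 (0.09 log units; within the scatter), small against the uncertainty.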

Compound 3, half-maximal inhibitory concentration: 33200 nM
For compound 3 the middle estimate is 1.1-fold (0.04 log units) below the measured one; the range from low to high includes it.
By their numbers in this assay, from the lowest: compound 2; then compounds 1 and 3 (each within the scatter of the next).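

Replacing 2,4-dichlorophenyl with 3,4-difluorophenyl on the amide-type nitrogen gives a 1.4-fold higher number from compound 1 to compound 3 (0.13 log units; within the scatter) in this assay. Among the compounds shown here, this is the first reading at the anilide part, and it shows that exchanging these two halogen-bearing phenyl groups, each with 8 heavy atoms, does not separate the two compounds, whereas the acetyl step on the other side of the molecule lies beyond the scatter. No measured evidence bears on this result.

As far as these compounds go, whether this position tolerates groups of other kinds remains open, for example an unsubstituted phenyl, a pyridyl ring or a phenyl carrying a carboxylic acid or an amine. It is also unknown whether acetyl on the aromatic nitrogen would give a similar step with 3,4-difluorophenyl in the anilide part.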